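The compounds below may be only part of what the source reports. "The series", "measured", "known", "first", "only" and "open" are said of these compounds alone.

Compound 1 `CN(C[C@H]1Cc2c(cccc2N2CCN(C3COC3)CC2)CN1)[C@H]1CCCc2cccnc21`: in a functional assay on CCRF-CEM cells for agonist activity at C-X-C chemokine receptor type 4 (Homo sapiens), read by calcium flux, with a stated time of 25 min (on this read-out lower numbers stand for an effect already at smaller amounts and higher numbers for an effect only at larger amounts of compound), compound 1 gives only a limit, > 30000 nM.
Compound 2 `C[C@@H]1CN(c2cccc3c2C[C@H](CN(C)[C@H]2CCCc4cccnc42)NC3)C[C@H](C)N1`: in this assay compound 2 likewise reaches only a limit, > 30000 nM.
Compound 3 `CC(C)N1CCN(c2cccc3c2C[C@H](CN(C)[C@H]2CCCc4cccnc42)NC3)CC1`: in this assay compound 3 also stops at a limit, > 30000 nM.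

Compound 3 therefore stands nowhere on a scale of numbers: all three results sit at the same limit, (the limit of > 30000 nM in this assay, at which 3 of the 3 values shown sit). The three steps among the measured compounds are accordingly unreadable in size and direction: a step that the two limits leave unreadable from compound 1 to compound 2, a step that the two limits leave unreadable from compound 1 to compound 3 and a step that the two limits leave unreadable from compound 2 to compound 3. Within the data shown here, exchanging the amine substituent on the aromatic carbon of the shared core has so far produced no compound whose effect can be read at all.

Compound 4 `CN(C[C@H]1Cc2c(cccc2N2CCN3CCC[C@H]3C2)CN1)[C@H]1CCCc2cccnc21` carries the next change at that same position: a group of 9 heavy atoms (7 carbon, 2 nitrogen; one five-membered non-aromatic ring with 1 hetero atom, one six-membered non-aromatic ring with 2 hetero atoms) in place of a group of 9 heavy atoms (7 carbon, 2 nitrogen; one six-membered non-aromatic ring with 2 hetero atoms), on an aromatic carbon. The entering group keeps the count of heavy atoms, the two nitrogens and the two hydrogen-bond acceptors of the departing isopropylpiperazine, and adds a five-membered ring with one defined stereocentre. All three measured steps bear on this change, and none gave a readable size; nothing among them points toward a readable effect for compound 4.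

Compound 4 is therefore expected to remain at or near the same limit in this assay, with an estimate of 30000 nM and a range from 8000 nM to 100000 nM. The expected step from compound 3 is a number no higher from compound 3 to compound 4 (the limit leaves the size open), that is, no change beyond the scatter.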

Compound 4, half-maximal effective concentration: > 30000 nM
Compound 4 gave a limit, no number; the forecaster's own chance of this, stated with the estimate: 85%; the middle value lies on the limit itself.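

In this assay compound 4 gives only a limit, > 30000 nM. Among these compounds, no step from compound 1, compound 2 or compound 3 to compound 4 can be read, in size or in direction: the limit of > 30000 nM in this assay, at which 4 of the 4 values shown sit. The compounds shown leave open whether any group on this aromatic carbon of the shared core gives a readable effect in this assay.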